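Pyridine Enters a Weak Hydrazone Series

A few compounds are considered here, and "the series" means these few. Any claim that something is new, unique, unknown or untested is made for them only; others in the source may bear on it.

Compound 1 `CCCSc1nc(N/N=C(\C)c2ccccc2O)c2nnn(Cc3ccc(Cl)cc3)c2n1` in a functional assay on MGC-803 cells (Homo sapiens) for antiproliferative activity, read by MTT assay, with a stated time of 72 h; a higher number here means a weaker inhibitor, a lower number a stronger inhibitor: 7100 nM
Compound 2 `CCCSc1nc(N/N=C/c2ccc(C)cc2)c2nnn(Cc3ccccc3)c2n1` in this assay: a limit only, > 64000 nM

Among the compounds with values here, compound 1 and compound 2 share a core and differ at two places at once, so no single step between them can be read. Compound 2 stands at the edge of what this assay reports: for compound 2 the assay gives only the limit > 64000 nM, meaning no number was reached (the limit of > 64000 nM in this assay, at which 1 of the 2 values shown sits). Going by these compounds, compound 1 gives an actual number, 7100 nM, but it carries two changes relative to compound 2, so what each change contributes stays open.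

Compound 3 `CCCSc1nc(N/N=C/c2cccnc2)c2nnn(Cc3ccccc3)c2n1` has not yet been measured. It differs from compound 2 by one change: pyridin-3-yl in place of 4-methylphenyl on a carbon with a double bond to nitrogen. Within the data shown here, nothing among the measured compounds tells how this swap acts, so no direction beyond the scatter can be claimed for it. Because compound 2 sits at the limit > 64000 nM, compound 3 is expected to stay weak as well, with the step of an at least 1.2-fold lower number from compound 2 to compound 3 (0.10 log units; that floor lies within the scatter) estimated as small. Compound 3 is therefore expected near 50000 nM, within a range from 15000 nM to 120000 nM.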

Compound 3, half-maximal inhibitory concentration: 38100 nM
Compound 3: the middle estimate sits 1.3-fold (0.12 log units) above what was measured; low and high end bracket the measured number.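

With pyridin-3-yl in place of 4-methylphenyl on a carbon with a double bond to nitrogen, the series has its first comparison of a single change, and in this assay that change reads as an at least 1.6-fold lower number from compound 2 to compound 3 (0.22 log units; that floor lies within the scatter). Compound 2 has only a limit rather than a number, so the true size of this step stays unknown and only its floor can be stated: the limit of > 64000 nM in this assay, at which 1 of the 3 values shown sits.

Compound 3 gives an actual number, 38100 nM, which shows that a six-membered aromatic ring with a hetero atom at this place can bring a value inside the range that this assay reports.

The change removes a methyl group and puts a ring nitrogen in at the same time, and the compounds shown cannot separate these two parts of the swap. A plain phenyl ring at this place would speak to the methyl group alone, while pyridin-4-yl would show whether the place of the ring nitrogen matters.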